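A few compounds are considered here, and "the series" means these few. Any claim that something is new, unique, unknown or untested is made for them only; others in the source may bear on it.

Within the data shown here, compound 2 `CCCCCCCc1nc(N)n(CC(=O)Nc2ccccc2)c1-c1ccccc1Br` gives 7900 nM in a functional assay on MIA PaCa-2 cells (Homo sapiens) for antiproliferative activity, read by MTT assay, with a stated time of 48 h (on this read-out higher numbers stand for weaker inhibition and lower numbers for stronger inhibition), the lowest of the two numbers measured so far; compound 1 `CCCCCc1nc(N)n(CC(=O)Nc2ccccc2)c1-c1ccccc1Br` gives 40600 nM in this assay, and the step of a 5.1-fold lower number from compound 1 to compound 2 (0.71 log units; beyond the scatter) separates them. Compound 3 `Nc1nc(CC2CCCC2)c(-c2ccccc2Br)n1CC(=O)Nc1ccccc1` differs from compound 2 by cyclopentyl in place of hexyl on a saturated chain carbon bound to an aromatic carbon. Among the measured compounds shown here, no measured step exchanges a chain for a ring, so only a 5.1-fold lower number from compound 1 to compound 2 (0.71 log units; beyond the scatter) bears on it, and that step gave a lower number on lengthening the chain, which suggests a shorter ring-bearing group may give a somewhat higher number. Compound 3 is therefore estimated at 15000 nM (range 5000 nM to 45000 nM), an expected step of a 1.9-fold higher number from compound 2 to compound 3 (0.28 log units; within the scatter).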

Compound 3, half-maximal inhibitory concentration: 61400 nM
Compound 3: middle estimate off by 4.1-fold (0.61 log units), on the low side, outside the stated range (above it).
By their numbers in this assay, from the lowest: compound 2; then compounds 1 and 3 (each within the scatter of the next).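

Cyclopentyl in place of hexyl at this position gives (a 7.8-fold higher number from compound 2 to compound 3 (0.89 log units; beyond the scatter)) in this assay, so the ring does not match the longer open chain of compound 2. Cyclopentyl in place of butyl gives (a 1.5-fold higher number from compound 1 to compound 3 (0.18 log units; within the scatter)), which leaves compound 3 and compound 1 indistinguishable in this assay. Nothing measured here accounts for these results. The compounds shown leave open whether an octyl chain would extend the difference seen between compound 1 and compound 2. They also leave open how a cyclohexyl ring or a chain ending in an amine would compare.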